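From 2-methyl to 2-isopropyl on the 1H-imidazol-1-yl group

The source may report more compounds than this note shows. Statements on the series, on what has been measured and on what is new or still open speak of the compounds shown alone.

For the measured compounds named here, in a functional assay on HUVEC cells (Homo sapiens), read by scintillation counting and thymidine incorporation, with a stated time of 24 h (on this read-out lower numbers stand for stronger inhibition and higher numbers for weaker inhibition), compound 1 (`CCC(C)n1ncn(-c2ccc(N3CCN(c4ccc(OC[C@@H]5CO[C@@](CN(C)C)(c6ccc(Cl)cc6Cl)O5)cc4)CC3)cc2)c1=O`) gives 1400 nM and compound 2 (`CCC(C)n1ncn(-c2ccc(N3CCN(c4ccc(OC[C@@H]5CO[C@@](Cn6ccnc6C)(c6ccc(Cl)cc6Cl)O5)cc4)CC3)cc2)c1=O`) gives 173 nM as the lower of the only two numbers so far. Compound 3 (`CCC(C)n1ncn(-c2ccc(N3CCN(c4ccc(OC[C@@H]5CO[C@@](Cn6ccnc6C(C)C)(c6ccc(Cl)cc6Cl)O5)cc4)CC3)cc2)c1=O`) differs from compound 2 in one group: isopropyl in place of methyl on an aromatic carbon with isopropyl in place of methyl on an aromatic carbon of the five-membered aromatic ring, between two ring nitrogen atoms.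

Going by the values given here, one measured step bears on this, and only indirectly. It is an 8.1-fold lower number from compound 1 to compound 2 (0.91 log units; beyond the scatter) with 2-methyl-1H-imidazol-1-yl in place of dimethylamino, a modest step beyond the scatter. Among the compounds with values here, that step exchanged the whole group, so it shows only that a change at this position can move the number. Within the data shown here, no measured pair changes the substituent on the imidazole itself, and the data give no firm direction. A small step is therefore expected, with a slight lean towards a higher number. The estimated move is a 1.2-fold higher number from compound 2 to compound 3 (0.08 log units; within the scatter) and it would stay within the scatter. Compound 3 is estimated at 210 nM in this assay with an expected range from 70 nM to 630 nM for now.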

Compound 3, half-maximal inhibitory concentration: 84 nM
The estimate for compound 3 lay 2.5-fold (0.40 log units) above the measured number; the measured number falls inside the stated range.
By their numbers in this assay, from the lowest: compound 3; then compound 2; then compound 1.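

In this assay, the substituent on the imidazole now has a measured effect of its own: a 2.1-fold lower number from compound 2 to compound 3 (0.31 log units; beyond the scatter), a modest step just beyond the scatter, for isopropyl in place of methyl on the aromatic carbon between two ring nitrogen atoms. The larger group, with 3 heavy atoms against 1, is therefore accepted at this position, and the number moves lower. Measured against the dimethylamino group, the whole exchange now gives a 17-fold lower number from compound 1 to compound 3 (1.22 log units; beyond the scatter), a large step where the exchange to 2-methyl-1H-imidazol-1-yl was modest, and nothing available explains the gain from methyl to isopropyl.

With only methyl and isopropyl shown at this position, two points give no trend, so it remains open whether the number falls further with tert-butyl or cyclopropyl, or rises again with phenyl. The imidazole with a plain hydrogen at this carbon, and a hydroxymethyl or aminomethyl group in the same place, would show whether size alone tracks with the number or whether the step from compound 2 to compound 3 is specific to isopropyl.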